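An Ethyl to Benzyl Swap in a Level Series

This account rests on a few compounds, and the source may have more. Where it says the series, first, only, none or still open, it means among the compounds named here.

Compound 1 (`COc1cccc2cc(-c3ccccc3)c(O)nc12`) gives 10000 nM in a functional assay on MCF7 cells (Homo sapiens) for cytotoxicity, read by colorimetric assay and MTT assay (on this read-out lower numbers stand for stronger inhibition and higher numbers for weaker inhibition), and compound 2 (`COc1ccc(-c2cc3cccc(OC)c3nc2O)cc1`) gives 10000 nM on the same read-out. Compound 3 (`CCOC(=O)Cn1c(=O)c(-c2ccc(OC)cc2)cc2c(OC)cc(OC)cc21`) stands at 10000 nM and so sits level with compound 1 and compound 2. Compound 4 (`COc1ccc(-c2cc3c(OC)cc(OC)cc3n(CC(=O)OCc3ccccc3)c2=O)cc1`) differs from compound 3 by phenyl in place of methyl on a saturated chain carbon bound to an oxygen next to a carbonyl group in the form of phenyl in place of methyl on a saturated chain carbon bound to an oxygen next to a carbonyl group, which turns ethoxycarbonyl into benzyloxycarbonyl. Within the data shown here, the one measured single change (no change at the digits printed from compound 1 to compound 2 (within the scatter)) puts methoxy in place of hydrogen on an aromatic carbon, so it is a different change at a different place. Among the measured compounds shown here, no measured step touches the ethoxycarbonyl group, and that step offers only loose guidance. Neither it nor the reading of compound 3 at 10000 nM gives ground to expect a shift beyond the scatter. The expected step is no change at the digits printed from compound 3 to compound 4 (within the scatter) in this assay with no direction favoured. For compound 4 the estimate is 10000 nM with an expected range from 4000 nM to 20000 nM until the measurement is in.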

Compound 4, half-maximal inhibitory concentration: 10000 nM
Beside the measured number, compound 4's estimate shows no gap at the digits printed, and the stated range covers the measured number.
By their numbers in this assay, from the lowest: compounds 1, 2, 3 and 4 (each within the scatter of the next).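

In this assay, among these compounds, the swap of ethoxycarbonyl for benzyloxycarbonyl gives no change at the digits printed from compound 3 to compound 4 (within the scatter), so the one measured step at the saturated chain carbon bound to an oxygen next to a carbonyl group shows that one six-membered aromatic ring of carbon only can enter there without moving the reading beyond the scatter. The earlier step concerned an aromatic carbon, so the absence of a shift now holds for two different changes at two different places, though each rests on a single pair. Nothing measured on these compounds accounts for this flat result.

The compounds shown leave open whether a carboxylic acid or an amide in place of the ethoxycarbonyl group would read any differently in this assay on the shared core. Also open, from the compounds shown here alone, is whether an amine at the end of a longer chain at this place would separate from the level reading.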